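A Larger Group Replaces 3,4-Dihydroxyphenyl

The compounds below may be only part of what the source reports. "The series", "measured", "known", "first", "only" and "open" are said of these compounds alone.

In a functional assay on MCF7 cells (Homo sapiens) for antiproliferative activity, read by MTT assay, with stated times of 24 h and 72 h (on this read-out higher numbers stand for weaker inhibition and lower numbers for stronger inhibition), compound 1 (`COc1cc(N2C(=O)[C@@H](Oc3ccccc3)[C@H]2c2ccc(N(C)C)cc2)cc(OC)c1OC`) gives 31000 nM, while compound 2 (`COc1cc(N2C(=O)[C@@H](Oc3ccccc3)[C@H]2c2ccc(O)c(O)c2)cc(OC)c1OC`) gives 4500 nM, the lower of the two numbers. Compound 3 (`COc1cc(N2C(=O)[C@@H](Oc3ccccc3)[C@H]2c2cc(O)c(OC)c([N+](=O)[O-])c2)cc(OC)c1OC`) has not yet been measured. It differs from compound 2 on a saturated ring carbon: a group of 12 heavy atoms (7 carbon, 1 nitrogen, 4 oxygen; one six-membered aromatic ring of carbon only) in place of a group of 8 heavy atoms (6 carbon, 2 oxygen; one six-membered aromatic ring of carbon only), on a saturated ring carbon. Among the measured compounds shown here, one measured step bears on this change: a 6.9-fold lower number from compound 1 to compound 2 (0.84 log units; beyond the scatter), with 3,4-dihydroxyphenyl in place of 4-(dimethylamino)phenyl on that same carbon. For the measured compounds named here, with only that modest step to go on, a change no larger than it is expected in this assay, leaning towards a lower number, though the direction is poorly fixed. The expected change is a 2.3-fold lower number from compound 2 to compound 3 (0.35 log units; beyond the scatter). For compound 3 the estimated value is 2000 nM, within an expected range of 300 nM to 15000 nM.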

Compound 3, half-maximal inhibitory concentration: 69000 nM
Estimate against measurement, compound 3: 35-fold (1.54 log units) below, outside the stated range (above it).
By their numbers in this assay, from the lowest: compound 2; then compound 1; then compound 3.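

In this assay, the result shows that the group on this saturated ring carbon can raise the number as well as lower it: a 15-fold higher number from compound 2 to compound 3 (1.19 log units; beyond the scatter) is a larger move than any seen before at this carbon. Among the compounds shown here, the group in compound 3 also falls behind 4-(dimethylamino)phenyl, with a 2.2-fold higher number from compound 1 to compound 3 (0.35 log units; beyond the scatter), so across these three compounds the number rises in the same order as the heavy atom count of the group, and no compound goes against that order. No measurement at hand accounts for the rise.

Compound 3 changes several features of the group at once, so its size cannot be separated from the identity of its substituents. As far as these compounds go, whether a carboxylic acid or a primary amine in place of the nitro group would restore the lower number stays open.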